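The source may hold more compounds than are shown below. What is called first, only, known or untested is meant among the compounds shown, and "the series" means these compounds.

Measured so far:
compound 1 `COc1nn(Cc2ccccc2-c2ccccc2)c(=O)o1`, 23%
compound 2 `COc1nn(Cc2cccc([N+](=O)[O-])c2)c(=O)o1`, 7%
compound 3 `COc1nn(Cc2ccc(N)cc2)c(=O)o1`, 34%

These three share one core and differ only in the group carried by the benzyl ring. In an assay on COS-7 cells for inhibition of Fatty-acid amide hydrolase 1 (Homo sapiens), read by scintillation counting, with a stated time of 10 min, tested at 10 uM (a lower number here means less inhibition, a higher number more inhibition at the concentration tested (going by the name of the read-out)), compound 1 gives 23%, which places it second highest of the three: compound 3 is higher by a gap beyond the scatter, and compound 2 is lower by a gap also beyond the scatter.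

Compound 4 `COc1nn(Cc2ccccc2NC(C)=O)c(=O)o1` has not yet been measured. It comes from compound 1 by one change: acetamido in place of phenyl on an aromatic carbon. For the measured compounds named here, no single-point step between measured compounds exists to guide the size of this change, so the expectation rests on the spread of the three values alone. The step of a number 3 percentage points lower from compound 1 to compound 4 (within the scatter) is expected to be small, within the scatter, and compound 4 is estimated at 20%, ranging from 5% to 38%.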

Compound 4, a percentage reported as inhibition, at one concentration (the size of the read-out at that concentration, not a potency): 11%
Estimate against measurement, compound 4: 9 percentage points above, and the stated range covers the measured number.
By their numbers in this assay, from the lowest: compounds 2 and 4 (each within the scatter of the next); then compound 1; then compound 3.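

In this assay, for the compounds shown here, putting acetamido in place of phenyl on this aromatic carbon gives a number 12 percentage points lower from compound 1 to compound 4 (beyond the scatter) as the first single-change comparison. This position therefore responds to the group it carries: inhibition changes beyond the scatter when a ring-free group with a hydrogen-bond donor and acceptor replaces an all-carbon aromatic ring. Nothing available explains why this step goes down.

From the compounds shown here alone, it remains open whether an amine or a longer chain at this same place would give a number closer to that of compound 1 or further from it.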